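Benzimidazole chalcone amides: trifluoromethyl for methyl

This account rests on a few compounds, and the source may have more. Where it says the series, first, only, none or still open, it means among the compounds named here.

Measured so far in a functional assay on HCT-116 cells (Homo sapiens) for antiproliferative activity, read by MTT assay, with a stated time of 48 h; on this read-out higher numbers stand for weaker inhibition and lower numbers for stronger inhibition:
compound 1 `O=C(/C=C/c1cccc(NC(=O)c2ccccc2Br)c1)c1nc2ccccc2[nH]1`, 1680 nM
compound 2 `Cc1ccccc1C(=O)Nc1cccc(/C=C/C(=O)c2nc3ccccc3[nH]2)c1`, 1870 nM
compound 3 `Cc1cccc(C(=O)Nc2cccc(/C=C/C(=O)c3nc4ccccc4[nH]3)c2)c1`, 1420 nM

Compound 3 sits at the low end of the three numbers in this assay, yet the steps of a 1.2-fold lower number from compound 1 to compound 3 (0.07 log units; within the scatter) and a 1.3-fold lower number from compound 2 to compound 3 (0.12 log units; within the scatter) both lie within the scatter, as does a 1.1-fold higher number from compound 1 to compound 2 (0.05 log units; within the scatter). Compound 4 `O=C(Nc1cccc(/C=C/C(=O)c2nc3ccccc3[nH]2)c1)c1cccc(C(F)(F)F)c1` differs from compound 3 by trifluoromethyl in place of methyl on an aromatic carbon. For the measured compounds named here, no measured step involves trifluoromethyl; the only changes seen on this benzamide ring, a bromo to methyl swap and a move of methyl between positions, all stayed within the scatter. Nothing here therefore supports a step beyond the scatter in this assay in either direction. Compound 4 is expected at 1500 nM, between 600 nM and 4000 nM, a step of a 1.1-fold higher number from compound 3 to compound 4 (0.02 log units; within the scatter) that is expected to stay within the scatter.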

Compound 4, half-maximal inhibitory concentration: 3360 nM
The estimate for compound 4 lay 2.2-fold (0.35 log units) below the measured number; the measured number falls inside the stated range.
By their numbers in this assay, from the lowest: compounds 3, 1, 2 and 4 (each within the scatter of the next, the first and the last beyond it).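

In this assay, for the compounds shown here, trifluoromethyl in place of methyl gives the first step on this benzamide ring that lies beyond the scatter (a 2.4-fold higher number from compound 3 to compound 4 (0.37 log units; beyond the scatter)), whereas all steps among the earlier compounds stayed within it. Compound 4 remains within the scatter of the other two compounds (a 1.8-fold higher number from compound 2 to compound 4 (0.25 log units; within the scatter); a 2.0-fold higher number from compound 1 to compound 4 (0.30 log units; within the scatter)), so the change registers only against compound 3 and remains modest. No available evidence bears on the reason for this step.

Open, on these data alone, is whether chloro, methoxy or an amine at this place would read like methyl or like trifluoromethyl. Also open, as far as these compounds go, is whether trifluoromethyl on another carbon of this ring would give the same step.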